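Nitro in place of methyl in a cell toxicity test

This account rests on a few compounds, and the source may have more. Where it says the series, first, only, none or still open, it means among the compounds named here.

Of the compounds shown here, three built on one shared core have been tested in a toxicity assay on THP-1 cells (Homo sapiens) for inhibition (on this read-out lower numbers stand for higher toxicity in this test and higher numbers for lower toxicity in this test), and one of them gives a true number. For the measured compounds named here, compound 2 `Cc1ccc(-c2cnc(NC(=O)c3ccc(F)cc3)n2C)cc1` stands at 60000 nM and is the only compound with a number so far. Compound 1 `COc1cccc(-c2cnc(NC(=O)c3ccc(F)cc3)n2C)c1` reads > 100000 nM and this is a limit of the assay. Compound 3 `Cc1cccc(-c2cnc(NC(=O)c3ccc(F)cc3)n2C)c1` reads > 100000 nM and this too is a limit.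

Compound 4 `Cn1c(-c2ccc([N+](=O)[O-])cc2)cnc1NC(=O)c1ccc(F)cc1` differs from compound 2 by nitro in place of methyl on an aromatic carbon, para to a large group (nitro in place of methyl on an aromatic carbon). The measured steps bear on this change only loosely, since none of them brings in nitro. One is an at least 1.6-fold lower number from compound 1 to compound 2 (0.22 log units; that floor lies within the scatter) and another is an at least 1.6-fold higher number from compound 2 to compound 3 (0.22 log units; that floor lies within the scatter) while the third is a step that the two limits leave unreadable from compound 1 to compound 3 and gives no size. As far as these compounds go, their reading is bounded by the limit of > 100000 nM in this assay, at which 2 of the 3 values shown sit, so their true sizes stay open.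

The expectation therefore starts from compound 2 at 60000 nM and stays close to it. In this assay the expected step is a 1.2-fold lower number from compound 2 to compound 4 (0.08 log units; within the scatter) and it is not expected to go beyond the scatter. The estimate for compound 4 is 50000 nM with an expected range of 20000 nM to 100000 nM in this test.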

Compound 4, half-maximal cytotoxic concentration: > 50000 nM
Compound 4 gave a limit, no number; the forecaster's own chance of this, stated with the estimate: 35%; the middle value lies on the limit itself.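

In this assay compound 4 reads > 50000 nM, which is a limit of the assay and not a number. For the compounds shown here, no step from compound 2 to compound 4 can therefore be read. The compounds shown leave open whether nitro in place of methyl on this aromatic carbon shifts the toxicity read-out at all, and in which direction.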